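Salicylanilide Cytotoxicity: From Ester to Second Amide

This account rests on a few compounds, and the source may have more. Where it says the series, first, only, none or still open, it means among the compounds named here.

Compound 1, `O=C(Nc1cccc(F)c1)c1cc(Cl)ccc1O`: 15000 nM
Compound 2, `O=C(Nc1cccc(Br)c1)c1cc(Cl)ccc1O`: 5700 nM
Compound 3, `CCOC(=O)c1cccc(NC(=O)c2cc(Cl)ccc2O)c1`: 17000 nM

In an ADME assay on cells (Macrophage, Mus musculus) for cytotoxicity, read by resazurin assay, with a stated time of 3 days (a higher number here means a weaker inhibitor, a lower number a stronger inhibitor), compound 3 gives the highest number of the three. Its nearest neighbour is compound 1, with a 1.1-fold higher number from compound 1 to compound 3 (0.05 log units; within the scatter); compound 2 is further away, with a 3.0-fold higher number from compound 2 to compound 3 (0.47 log units; beyond the scatter). Compound 4, `O=C(Nc1ccccc1)c1cccc(NC(=O)c2cc(Cl)ccc2O)c1`, differs from compound 3 by anilino in place of ethoxy on a carbonyl carbon. Going by the values given here, no measured step alters the ethoxycarbonyl itself; the known steps only swap the group on the aromatic carbon, and they span at most a modest change. The expectation for compound 4 in this assay is therefore a step of about a 1.1-fold lower number from compound 3 to compound 4 (0.05 log units; within the scatter), which lies within the scatter. Compound 4 is estimated at 15000 nM, in a range from 6000 nM to 40000 nM.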

Compound 4, half-maximal inhibitory concentration: > 60000 nM
Compound 4 ended at the assay's limit; the forecaster's own chance of this, stated with the estimate: 15%; middle value at least 4.0-fold (0.60 log units) from the limit.
By their numbers in this assay, from the lowest: compound 2; then compounds 1 and 3 (each within the scatter of the next). At a limit, above all of these: compound 4.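

In this assay, compound 4 gives > 60000 nM, which is a limit of the assay and not a number: the limit of > 60000 nM in this assay, at which 1 of the 4 values shown sits. Anilino in place of ethoxy on the carbonyl carbon gives an at least 3.5-fold higher number from compound 3 to compound 4 (0.54 log units; beyond the scatter), so this carbonyl position responds in a way the earlier compounds could not show, as their steps only swapped the group on the aromatic carbon. The size of this step has only a lower bound.

The compounds shown leave open whether a simple alkyl amine or a carboxylic acid in place of the ethoxy would also raise the number. They also leave open how much of the step comes from the aromatic ring of the anilino and how much from its nitrogen.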